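A few compounds are considered here, and "the series" means these few. Any claim that something is new, unique, unknown or untested is made for them only; others in the source may bear on it.

Of the compounds shown here, three sharing one core have been tested in a toxicity assay on Vero cells (Chlorocebus sabaeus) for cytotoxicity; a lower number here means that less compound is tolerated, a higher number that more compound is tolerated. Compound 1 `O=C(/C=C/c1ccc([N+](=O)[O-])o1)c1ccc(F)cc1` gives 463000 nM. Compound 2 `O=C(/C=C/c1ccc([N+](=O)[O-])o1)c1ccc(Cl)cc1` gives 558000 nM, and compound 3 `O=C(/C=C/c1ccc([N+](=O)[O-])o1)c1ccc(OCc2ccccc2)cc1` gives 515000 nM. The changes at the outer ring so far, a 1.2-fold higher number from compound 1 to compound 2 (0.08 log units; within the scatter), a 1.1-fold higher number from compound 1 to compound 3 (0.05 log units; within the scatter) and a 1.1-fold lower number from compound 2 to compound 3 (0.03 log units; within the scatter), all stayed within the scatter, so on these numbers compound 3 cannot be told apart from compound 1 or compound 2.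

Compound 4 `O=C(/C=C/c1ccc([N+](=O)[O-])o1)c1ccc(OCc2ccc(F)cc2)cc1` differs from compound 3 by fluoro in place of hydrogen on an aromatic carbon. Among the compounds with values here, no measured step touches this outer position; the nearest comparisons are the swaps on the inner ring already mentioned, which changed nothing beyond the scatter. On that basis no step beyond the scatter is expected in this assay, and the estimate is a 1.0-fold lower number from compound 3 to compound 4 (0.01 log units; within the scatter). Compound 4 is therefore expected to give about 500000 nM, with a plausible range from 250000 nM to 1000000 nM.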

Compound 4, half-maximal cytotoxic concentration: 430000 nM
For compound 4 the middle estimate is 1.2-fold (0.07 log units) above the measured one; measured number inside the range.
By their numbers in this assay, from the lowest: compounds 4, 1, 3 and 2 (each within the scatter of the next).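

In this assay, within the data shown here, this is the first change on the outer ring of the benzyloxy group: fluoro on an aromatic carbon, para to a large group, gives a 1.2-fold lower number from compound 3 to compound 4 (0.08 log units; within the scatter), so this single added atom cannot be told from hydrogen here. The complete (4-fluorobenzyl)oxy group also cannot be told from the simple halogens it replaces, with a 1.3-fold lower number from compound 2 to compound 4 (0.11 log units; within the scatter) and a 1.1-fold lower number from compound 1 to compound 4 (0.03 log units; within the scatter), so all four compounds now sit within the scatter of one another. No evidence is available that explains why these numbers stay so close.

All the groups shown on the outer ring are halogens or benzyl ethers. Going by these compounds, whether an amine or a carboxylic acid at this position would move the number beyond the scatter remains open, as does the effect of any change to the shared core.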